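Replacing a methyl with 2-oxopropoxy on a coumarin inhibitor

The source may report more compounds than this note shows. Statements on the series, on what has been measured and on what is new or still open speak of the compounds shown alone.

Compound 1 `Cc1cccc(-c2cc3cc(C)ccc3oc2=O)c1`: 15 nM
Compound 2 `Cc1ccc2oc(=O)c(-c3ccccc3O)cc2c1`: 120 nM

In an in vitro assay on cells for inhibition of Amine oxidase [flavin-containing] B (Homo sapiens), read by fluorescence and Amplex Red, with a stated time of 15 min (a lower number here means a stronger inhibitor, a higher number a weaker inhibitor), compound 1 gives 15 nM, the lowest of the two numbers. Compound 2 gives 120 nM, a weaker result that lies beyond the scatter. Compound 3 `CC(=O)COc1cccc(-c2cc3cc(C)ccc3oc2=O)c1` is not yet measured; it differs from compound 1 by 2-oxopropoxy in place of methyl on an aromatic carbon. For the measured compounds named here, no measured pair shows this exact change, so only a small step is expected, in no clear direction beyond the scatter: a 1.3-fold higher number from compound 1 to compound 3 (0.12 log units; within the scatter). Compound 3 is therefore estimated at 20 nM, within a range from 6 nM to 70 nM.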

Compound 3, half-maximal inhibitory concentration: 180 nM
Compound 3: the middle estimate sits 9.0-fold (0.95 log units) below what was measured; the whole stated range lies below it.
By their numbers in this assay, from the lowest: compound 1; then compounds 2 and 3 (each within the scatter of the next).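

In this assay, putting 2-oxopropoxy in place of the methyl on this aromatic carbon gives a 12-fold higher number from compound 1 to compound 3 (1.08 log units; beyond the scatter), a large loss of strength. The earlier compounds shown here could not show this, and it means that this position does not accept this longer group without cost. No available measurement gives a reason for the loss.

As far as these compounds go, it remains open whether a methoxy group or an amine at this position would keep the strength of compound 1. From the compounds shown here alone, it also remains open whether a plain ether chain of the same length, without the carbonyl, would lose as much.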